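Swapping a sulfonamide for a propyl chain on a triazole side arm

This account rests on a few compounds, and the source may have more. Where it says the series, first, only, none or still open, it means among the compounds named here.

Compound 1, `O=C1O[C@H]([C@@H](O)Cn2cc(CCO)nn2)C(OCc2ccccc2)=C1OCc1ccccc1`: > 100000 nM in a functional assay on CFPAC-1 cells (Homo sapiens) for antiproliferative activity, read by MTT assay, with a stated time of 72 h; a higher number here means a weaker inhibitor, a lower number a stronger inhibitor; this is a limit of the assay, not a number.
Compound 2, `O=C1O[C@H]([C@@H](O)Cn2cc(C3CC3)nn2)C(OCc2ccccc2)=C1OCc1ccccc1`: 47700 nM in this assay.
Compound 3, `O=C1O[C@H]([C@@H](O)Cn2cc(CNS(=O)(=O)c3ccc(Cl)cc3)nn2)C(OCc2ccccc2)=C1OCc1ccccc1`: 38900 nM in this assay.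

Among the two numbers shown, compound 3 has the lowest, and the step between them is a 1.2-fold lower number from compound 2 to compound 3 (0.09 log units; within the scatter). From the compounds shown here alone, the step from compound 1 is larger: an at least 2.5-fold lower number from compound 1 to compound 3 (0.41 log units; beyond the scatter), though compound 1 sits at a limit, (the limit of > 100000 nM in this assay, at which 1 of the 3 values shown sits), so the true size is unknown.

Compound 4, `CCCCc1cn(C[C@H](O)[C@H]2OC(=O)C(OCc3ccccc3)=C2OCc2ccccc2)nn1`, differs from compound 3 by propyl in place of ((4-chlorophenyl)sulfonyl)amino on a saturated chain carbon bound to an aromatic carbon. The closest guide is compound 2, whose cyclopropyl on the aromatic carbon gives a number within the scatter of compound 3. A plain hydrocarbon chain here, then, seems to cost little, so the step of a 1.2-fold higher number from compound 3 to compound 4 (0.06 log units; within the scatter) is expected to stay close to the scatter, leaning slightly weaker. Compound 4 is therefore estimated at 45000 nM, with a likely range from 15000 nM to 150000 nM in this assay.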

Compound 4, half-maximal inhibitory concentration: 73200 nM
Estimate against measurement, compound 4: 1.6-fold (0.21 log units) below; low and high end bracket the measured number.
By their numbers in this assay, from the lowest: compounds 3, 2 and 4 (each within the scatter of the next). At a limit, above all of these: compound 1.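

Replacing the whole ((4-chlorophenyl)sulfonyl)amino group, aromatic ring included, with propyl leaves the two compounds within the scatter of each other in this assay (a 1.9-fold higher number from compound 3 to compound 4 (0.27 log units; within the scatter)). Going by these compounds alone, this is the first sign that the sulfonamide is not needed to hold the number at this place, and a plain butyl chain likewise cannot be told apart from cyclopropyl (a 1.5-fold higher number from compound 2 to compound 4 (0.19 log units; within the scatter)). The remaining step (an at least 1.3-fold lower number from compound 1 to compound 4 (0.13 log units; that floor lies within the scatter)) starts from a limit and not a number, so its size cannot be read: the limit of > 100000 nM in this assay, at which 1 of the 4 values shown sits.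

It remains open whether an amine, a carboxylic acid or a chain longer than butyl on the same aromatic carbon would move the number beyond the scatter of these compounds. From the compounds shown here alone, how much the hydroxy group of compound 1 truly costs also stays unknown.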